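Swapping chloro for fluoro on an aromatic carbon

The source may report more compounds than this note shows. Statements on the series, on what has been measured and on what is new or still open speak of the compounds shown alone.

Measured in an ADME assay on MT4 cells (Homo sapiens) for cytotoxicity, read by MTT assay, with a stated time of 96 h; a higher number here means that more compound is tolerated, a lower number that less compound is tolerated:
- Compound 1 `Cc1ccc(C2CC(c3ccc(Oc4ccccc4)cc3)=NN2c2ccc(S(N)(=O)=O)cc2)cc1`: 7200 nM
- Compound 2 `NS(=O)(=O)c1ccc(N2N=C(c3ccc(OCc4ccccc4)cc3)CC2c2ccccc2F)cc1`: 39000 nM
- Compound 3 `NS(=O)(=O)c1ccc(N2N=C(c3ccc(Oc4ccccc4)cc3)CC2c2ccccc2Cl)cc1`: 40000 nM

Compound 3, at 40000 nM, cannot be told apart from compound 2, at 39000 nM. The two values lie within the usual scatter of repeated measurements. Compound 1 is the clear low point of the set, and the gap is shown by a 5.6-fold higher number from compound 1 to compound 3 (0.74 log units; beyond the scatter).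

The next compound, compound 4 `NS(=O)(=O)c1ccc(N2N=C(c3ccc(Oc4ccccc4)cc3)CC2c2ccccc2F)cc1`, keeps compound 3 intact except for one substituent, with fluoro in place of chloro on an aromatic carbon. The group therefore changes from 2-chlorophenyl to 2-fluorophenyl.

Within the data shown here, only one measured step bears on this change. It is a 5.6-fold higher number from compound 1 to compound 3 (0.74 log units; beyond the scatter), a modest step beyond the scatter, and it replaced 4-methylphenyl with 2-chlorophenyl, a larger edit than this one. No measurement compares fluoro with chloro directly. Compound 2 also carries 2-fluorophenyl and gives 39000 nM, so high tolerance is seen with that group in one other compound. No step beyond the scatter is therefore expected in this assay, in either direction.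

The expected change is a 1.1-fold lower number from compound 3 to compound 4 (0.06 log units; within the scatter). Compound 4 is estimated at 35000 nM, with an expected range of 15000 nM to 80000 nM.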

Compound 4, half-maximal cytotoxic concentration: 36000 nM
For compound 4 the middle estimate is 1.0-fold (0.01 log units) below the measured one; the measured number falls inside the stated range.
By their numbers in this assay, from the lowest: compound 1; then compounds 4, 2 and 3 (each within the scatter of the next).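

In this assay, among these compounds, the step from chloro to fluoro on this aromatic carbon is a 1.1-fold lower number from compound 3 to compound 4 (0.05 log units; within the scatter), the first direct comparison of the two halogens here, and it shows no readable difference between them. With 2-fluorophenyl held constant, the step with phenyl in place of benzyl on the oxygen is a 1.1-fold lower number from compound 2 to compound 4 (0.03 log units; within the scatter), so that edit cannot be read as a difference either, while 2-fluorophenyl in place of 4-methylphenyl gives a 5.0-fold higher number from compound 1 to compound 4 (0.70 log units; beyond the scatter), a step beyond the scatter in the same direction as a 5.6-fold higher number from compound 1 to compound 3 (0.74 log units; beyond the scatter) with 2-chlorophenyl. The compounds shown come with no measurement that explains any of these results.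

On these data alone, it remains open whether a halogen matters at all on this ring, since a plain phenyl, a 2-methylphenyl or an amine on the same aromatic carbon could give a quite different number. Also open, as far as these compounds go, is whether the lower number of compound 1 belongs to the methyl group or to where it sits, as the steps from compound 1 change the group and its place at once.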